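The source may hold more compounds than are shown below. What is called first, only, known or untested is meant among the compounds shown, and "the series" means these compounds.

Measured compounds:
compound 1 `COc1ccc2c(c1)c(-c1cc(C(F)(F)F)c(C#N)c(-c3cn(S(=O)(=O)c4ccc(C)cc4)c4ccc(OC)cc34)n1)cn2S(=O)(=O)c1ccc(C)cc1` — 17.7%
compound 2 `Cc1ccc(S(=O)(=O)n2cc(-c3cc(C(F)(F)F)ccn3)c3ccccc32)cc1` — 30.5%
compound 3 `Cc1ccc(S(=O)(=O)n2cc(-c3cc(C(F)(F)F)cc(-c4cn(S(=O)(=O)c5ccc(C)cc5)c5ccccc45)n3)c3ccccc32)cc1` — 69.3%

In a functional assay on A549 cells (Homo sapiens) for inhibition, tested at 100 uM (a lower number here means a weaker effect, a higher number a stronger effect of the compound at the concentration tested), compound 1 stands lowest of the three numbers. Its nearest neighbour is compound 2, whose number lies higher by more than the scatter, and the furthest is compound 3, whose number lies higher by a wide margin, also beyond the scatter. No pair of these compounds differs in one place, so no single step has been measured.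

Compound 4 `COc1ccc2c(c1)c(-c1cc(C(F)(F)F)cc(-c3cn(S(=O)(=O)c4ccc(C)cc4)c4ccc(OC)cc34)n1)cn2S(=O)(=O)c1ccc(C)cc1` is not yet measured. It differs from compound 1 as follows: hydrogen in place of cyano on an aromatic carbon. The change removes the cyano that sits ortho to the trifluoromethyl group, two atoms from the ring nitrogen of the shared core.

Compound 3, which carries no cyano on its core, gives 69.3% in this assay, while compound 1 with the cyano gives the lowest number; compound 4 is expected to move upward from compound 1, by a step of a number 30.3 percentage points higher from compound 1 to compound 4 (beyond the scatter), a change expected to lie beyond the scatter. For compound 4 the estimate in this assay is 48%, with a range of 22% to 72%. Among the compounds with values here, the range is wide because the only guide is compound 3, whose value 69.3% comes from a core lacking the methoxy groups of compound 4.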

Compound 4, a percentage reported as inhibition, at one concentration (the size of the read-out at that concentration, not a potency): 41.7%
Compound 4: the middle estimate sits 6.3 percentage points above what was measured; the range from low to high includes it.
By their numbers in this assay, from the lowest: compound 1; then compound 2; then compound 4; then compound 3.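

In this assay, the position ortho to a trifluoromethyl group and two atoms from the ring nitrogen now has its first measured step, with hydrogen in place of cyano on an aromatic carbon: a number 24 percentage points higher from compound 1 to compound 4 (beyond the scatter). Within the data shown here, the earlier compounds included no pair differing in one place, so this is the first change in the read-out that can be tied to a single group. On this methoxy-bearing core, the cyano goes with the lower number, and the step lies beyond the scatter. No measurement shown bears on the reason for this step.

Going by these compounds, whether the same step would appear on a core without the methoxy groups remains open. So does the outcome of placing an amine, a carboxylic acid or a primary amide on this aromatic carbon.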